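Glucoside removal in a disulfide-linked fluorouracil conjugate

A few compounds are considered here, and "the series" means these few. Any claim that something is new, unique, unknown or untested is made for them only; others in the source may bear on it.

Measured compounds:
compound 1 `O=C(CCCCCN1C(=O)CC(SCCOCCOCCOc2cc(O)c(C(=O)CCc3ccc(O)cc3)c(O[C@@H]3O[C@H](CO)[C@@H](O)[C@H](O)[C@H]3O)c2)C1=O)OCn1cc(F)c(=O)[nH]c1=O`: 97400 nM
compound 2 `O=C(CCCSSCCOCCOCCOc1cc(O)c(C(=O)CCc2ccc(O)cc2)c(O[C@@H]2O[C@H](CO)[C@@H](O)[C@H](O)[C@H]2O)c1)OCn1cc(F)c(=O)[nH]c1=O`: 54900 nM

In a functional assay on HCT-116 cells (Homo sapiens) for cytotoxicity, read by sulforhodamine B assay, with a stated time of 48 h (on this read-out lower numbers stand for stronger inhibition and higher numbers for weaker inhibition), compound 1 gives 97400 nM and compound 2 gives 54900 nM. Compound 2 holds the lower of the two numbers, yet the gap to compound 1 lies within the scatter, so no order between them is claimed. Compound 3 `O=C(CCCSSCCOCCOCCOc1cc(O)c(C(=O)CCc2ccc(O)cc2)c(O)c1)OCn1cc(F)c(=O)[nH]c1=O` is not yet measured. It differs from compound 2 by hydrogen in place of 3,4,5-trihydroxy-6-(hydroxymethyl)oxan-2-yl on an oxygen on an aromatic ring. For the measured compounds named here, no measured pair shows this change, so the expected step of a 1.4-fold lower number from compound 2 to compound 3 (0.14 log units; within the scatter) is small, if anything toward a lower number. Compound 3 is estimated at 40000 nM, within 15000 nM to 120000 nM.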

Compound 3, half-maximal inhibitory concentration: 21200 nM
The estimate for compound 3 lay 1.9-fold (0.28 log units) above the measured number; measured number inside the range.
By their numbers in this assay, from the lowest: compound 3; then compounds 2 and 1 (each within the scatter of the next).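

In this assay, for the compounds shown here, the loss of the 3,4,5-trihydroxy-6-(hydroxymethyl)oxan-2-yl group from an oxygen on an aromatic ring gives a 2.6-fold lower number from compound 2 to compound 3 (0.41 log units; beyond the scatter) and so provides the first step in this set that lies beyond the scatter. In this one pair, the glucoside is not needed for the activity, and the free hydroxy compound reads modestly stronger. Nothing shown accounts for the step.

On these data alone, whether a methyl group or a longer chain on that oxygen would read differently stays open. So does whether the same removal would give a similar step with the linker of compound 1.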